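A few compounds are considered here, and "the series" means these few. Any claim that something is new, unique, unknown or untested is made for them only; others in the source may bear on it.

The compounds measured in an ADME assay on Raji cells (Homo sapiens) for cytotoxicity, read by CellTiter-Glo and resazurin assay, with a stated time of 72 h; on this read-out lower numbers stand for an effect already at smaller amounts and higher numbers for an effect only at larger amounts of compound:

Compound 1 `COc1cc(F)cc(-c2ccc(C(=O)N(Cc3cccc(OCCCCCC(=O)O)c3)C(C)C)cc2)c1`: > 26000 nM, a limit of the assay rather than a number.
Compound 2 `CCOC(=O)CCCCCOc1cccc(CN(C(=O)c2ccccc2)C(C)C)c1`: > 26000 nM, likewise a limit.
Compound 3 `CCOC(=O)CCCCCOc1cccc(CN(C(=O)c2ccc(-c3ccc(C(C)=O)s3)cc2)C(C)C)c1`: > 26000 nM, likewise a limit.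

All three values sit at the limit of > 26000 nM in this assay, at which 3 of the 3 values shown sit, so no number is known for any of them. Compound 3 therefore stands at the limit, and the two other values shown are limits as well. Because the step that the two limits leave unreadable from compound 2 to compound 3 runs between two limits, its size cannot be read, even though the structural change it describes, 5-acetylthiophen-2-yl in place of hydrogen on an aromatic carbon, is a sizeable one.

Compound 4 `CCOC(=O)CCCCCOc1cccc(CN(C(=O)c2ccc(-c3cc(F)cc(OC)c3)cc2)C(C)C)c1` differs from compound 3 by 3-fluoro-5-methoxyphenyl in place of 5-acetylthiophen-2-yl on an aromatic carbon. Compound 1 carries the same 3-fluoro-5-methoxyphenyl group and shows only the limit > 26000 nM. Among the compounds with values here, no measured step has a readable size, so nothing points to an effect beyond the scatter. The step that the limit leaves unreadable from compound 3 to compound 4 is therefore expected to be small. Compound 4 is estimated at 40000 nM, with a range from 20000 nM to 100000 nM, and is expected most likely to come back as a limit once more.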

Compound 4, half-maximal effective concentration: > 26000 nM
Compound 4 ended at the assay's limit; the forecaster's own chance of this, stated with the estimate: 85%; the middle value does not contradict the limit.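

Compound 4 ends at a limit of the assay, just as compound 1, compound 2 and compound 3 do, so no step among these four can be read: (the limit of > 26000 nM in this assay, at which 4 of the 4 values shown sit). Still open is whether in this assay any of these compounds has a measurable effect, and whether the groups exchanged among them change it.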